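The source may report more compounds than this note shows. Statements on the series, on what has been measured and on what is new or still open speak of the compounds shown alone.

Compound 2, whose structure is `CC(C)N1CCc2nc(C#Cc3ccccc3)ccc2C1=O`, gives the stronger of the two results recorded so far. In an assay on HEK293 cells for displacement of a labelled ligand from metabotropic glutamate receptor 5 (Homo sapiens), with a stated time of 2 h (on this read-out higher numbers stand for weaker inhibition and lower numbers for stronger inhibition), compound 2 gives 1280 nM, while compound 1, with the structure `COc1cccc(C#Cc2ccc3c(n2)CCN(C)C3=O)c1`, gives in this assay 3660 nM; the gap between these two is beyond the usual scatter, but since the two structures differ in more than one place no single change can be credited with it. Compound 3, with the structure `CC(C)N1CCc2nc(C#Cc3ccc(Cl)cc3)ccc2C1=O`, has not yet been measured in this assay. Its relation to compound 2 is a single change: chloro in place of hydrogen on an aromatic carbon, the chloro sitting on an aromatic carbon of a six-membered aromatic ring of carbon only, para to a large group. No measured pair in this set shows this change on its own, so there is no shown step to lean on. On this footing the step from compound 2 to compound 3 in this assay is expected to be modest, a 1.5-fold lower number from compound 2 to compound 3 (0.18 log units; within the scatter), and may not exceed the scatter. Compound 3 is therefore estimated at 850 nM in this assay, with a range from 250 nM to 2800 nM.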

Compound 3, inhibition constant: 27100 nM
The estimate for compound 3 lay 32-fold (1.50 log units) below the measured number, and the stated range ends below it.
By their numbers in this assay, from the lowest: compound 2; then compound 1; then compound 3.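

In this assay, for the compounds shown here, the change from phenyl to 4-chlorophenyl is the first change in this set that can be read on its own, and it gives a 21-fold higher number from compound 2 to compound 3 (1.33 log units; beyond the scatter) in the direction of weaker inhibition. The place on the six-membered aromatic ring of carbon only, para to a large group, is therefore not indifferent here: one entering chlorine atom, with no ring, no hydrogen-bond donors or acceptors and no net charge, is enough for a large step beyond the scatter. Nothing available here accounts for the size of this step.

On these data alone, what remains open is whether this loss belongs to chloro in particular or follows from any group at this place, a question that fluoro, methyl or a nitrile on the same carbon could help to settle, as could chloro on another carbon of the ring. The compounds shown also leave open whether the same change would have a step of similar size on the core of compound 1, where the ring already carries a methoxy group.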